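The compounds below may be only part of what the source reports. "The series", "measured", "known", "first", "only" and "open" are said of these compounds alone.

In a functional assay on the whole organism for antagonist activity, with Mus musculus as the target (on this read-out lower numbers stand for an effect already at smaller amounts and higher numbers for an effect only at larger amounts of compound), the measured compounds stand as follows.
Compound 1 `CCCCCCCN1CCC(C(=O)Nc2cc(Cl)c(N)cc2OC)CC1` gives > 10 mg/kg, which is a limit of the assay and not a number.
Compound 2 `COc1cc(N)c(Cl)cc1NC(=O)C1CCN(C/C=C/c2ccccc2)CC1` gives > 10 mg/kg, likewise only a limit.
Compound 3 `CCC(CC)CN1CCC(C(=O)Nc2cc(Cl)c(N)cc2OC)CC1` gives > 10 mg/kg, again a limit rather than a number.

Compound 3 therefore sits at the limit of > 10 mg/kg in this assay, at which 3 of the 3 values shown sit, together with the other two. The three measured steps, a step that the two limits leave unreadable from compound 1 to compound 2, a step that the two limits leave unreadable from compound 1 to compound 3 and a step that the two limits leave unreadable from compound 2 to compound 3, each run between two limits and give no readable size.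

Compound 4 `CCN1CCC(C(=O)Nc2cc(Cl)c(N)cc2OC)CC1` differs from compound 3 by methyl in place of pentan-3-yl on a saturated chain carbon bound to an amine nitrogen in a ring. Within the data shown here, no measured step gives a readable size for a change at this place, so the expected step that the limit leaves unreadable from compound 3 to compound 4 in this assay cannot be sized from them, and compound 4 is expected most likely to return a limit as well. The estimate for compound 4 in this assay is 15 mg/kg, with a range from 3 mg/kg to 60 mg/kg.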

Compound 4, dose for half-maximal effect: > 10 mg/kg
Compound 4: no number, only a limit; the forecaster's own chance of this, stated with the estimate: 70%; the middle value does not contradict the limit.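

Compound 4 ends at a limit, as do compound 1, compound 2 and compound 3, so no step among them can be read in this assay: the limit of > 10 mg/kg in this assay, at which 4 of the 4 values shown sit.

The compounds shown leave open whether any group at this place gives a readable dose, and how these groups would rank.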